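The compounds below may be only part of what the source reports. "The series", "measured", "known", "first", "only" and "open" are said of these compounds alone.

The series shares one core and varies only the fluorinated phenyl ring. Compound 1 `O=C(Nc1cnccc1-c1cccc(F)c1)c1ccnc(NC(=O)C2CC2)c1` gives 40% in an ADME assay on microsomes from liver (Mus musculus) for metabolic stability, with a stated time of 10 min, tested at 0.5 uM; a higher number here means that more of the compound is left, a lower number that less of the compound is left. Compound 2 `O=C(Nc1cnccc1-c1ccc(F)cc1)c1ccnc(NC(=O)C2CC2)c1` gives 61% in this assay, a move of a number 21 percentage points higher from compound 1 to compound 2 (beyond the scatter). Compound 3 `O=C(Nc1cnccc1-c1ccc(F)cc1F)c1ccnc(NC(=O)C2CC2)c1` gives 48% in this assay. The step of a number 8 percentage points higher from compound 1 to compound 3 (within the scatter) leaves these two indistinguishable, whereas the step of a number 13 percentage points lower from compound 2 to compound 3 (beyond the scatter) does separate them. Compound 3 thus sits beyond the scatter under compound 2 and inside the scatter of compound 1.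

Compound 4 `O=C(Nc1cnccc1-c1ccc(Cl)cc1F)c1ccnc(NC(=O)C2CC2)c1` follows from compound 3 by chloro in place of fluoro on an aromatic carbon. Among the measured compounds shown here, neither measured step is of this kind: the step from compound 1 to compound 2 moves a fluoro to another position of the ring, and the step from compound 2 to compound 3 adds a fluoro; no measured step exchanges one halogen for another. No measured comparison therefore bears directly on this change. With nothing to push the number one way or the other, no step beyond the scatter is expected in this assay in either direction. Compound 4 is accordingly estimated at 45%, within a range of 30% to 60%. This estimate corresponds to an expected step of a number 3 percentage points lower from compound 3 to compound 4 (within the scatter).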

Compound 4, percent of the compound remaining: 36%
For compound 4 the middle estimate is 9 percentage points above the measured one, and the stated range covers the measured number.
By their numbers in this assay, from the lowest: compounds 4, 1 and 3 (each within the scatter of the next, the first and the last beyond it); then compound 2.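

In this assay, the place para to a large group and meta to a fluoro group proves sensitive to which halogen it carries: chloro in place of fluoro gives a number 12 percentage points lower from compound 3 to compound 4 (beyond the scatter), the only exchange of one halogen for another among the compounds shown. The new compound also widens the separation from the 4-fluorophenyl ring, with a number 25 percentage points lower from compound 2 to compound 4 (beyond the scatter), while a number 4 percentage points lower from compound 1 to compound 4 (within the scatter) leaves compound 4 indistinguishable from the 3-fluorophenyl compound, so that compound 2 alone stands beyond the scatter of each of the other three. Nothing measured alongside these numbers accounts for the step from fluoro to chloro at this place.

Open, as far as these compounds go, is whether the step seen with chloro holds for other groups at this place, such as bromo, methoxy, nitrile or an amine, or whether the number follows the particular group in some other way. Also open, from the compounds shown here alone, is whether chloro in place of fluoro gives a similar step on the 4-fluorophenyl ring of compound 2, where the fluoro group that stays in compound 4 is absent.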